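The source may report more compounds than this note shows. Statements on the series, on what has been measured and on what is new or still open speak of the compounds shown alone.

Three compounds share a common core, differing only in the group carried on an aromatic carbon of the five-membered aromatic ring with 1 sulfur. In an ADME assay on MDCK cells (Canis lupus familiaris) for cytotoxicity, read by microscopy, with a stated time of 48 h (on this read-out lower numbers stand for higher toxicity in this test and higher numbers for lower toxicity in this test), compound 1 `CCCc1csc(CN[C@@H]2C[C@H]3C[C@@H]([C@H]2C)C3(C)C)c1` gives 12500 nM, compound 2 `C[C@H]1[C@H](NCc2cc(C3CCCCC3)cs2)C[C@H]2C[C@@H]1C2(C)C` gives 780 nM, and compound 3 `C=Cc1csc(CN[C@@H]2C[C@H]3C[C@@H]([C@H]2C)C3(C)C)c1` gives 6250 nM. Compound 3 stands second highest of the three numbers; its nearest neighbour is compound 1, and the step of a 2.0-fold lower number from compound 1 to compound 3 (0.30 log units; within the scatter) lies within the scatter, while the step of an 8.0-fold higher number from compound 2 to compound 3 (0.90 log units; beyond the scatter) is beyond it.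

Compound 4 `C[C@H]1[C@H](NCc2cc(C3CCCC3)cs2)C[C@H]2C[C@@H]1C2(C)C` differs from compound 3 by cyclopentyl in place of vinyl on an aromatic carbon. Among the compounds with values here, two measured steps bear on this change: the step of a 16-fold lower number from compound 1 to compound 2 (1.20 log units; beyond the scatter) and the step of an 8.0-fold higher number from compound 2 to compound 3 (0.90 log units; beyond the scatter), both showing that a ring of carbon in this position goes with a markedly lower number in this assay than a short chain. Within the data shown here, since cyclopentyl is a ring smaller than cyclohexyl, a lower number for compound 4 is expected, though a smaller step than the one from compound 3 to compound 2, giving an estimated step of a 3.9-fold lower number from compound 3 to compound 4 (0.59 log units; beyond the scatter). Compound 4 is therefore expected to give about 1600 nM, with a range from 600 nM to 4000 nM.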

Compound 4, minimum cytotoxic concentration: 1560 nM
The estimate for compound 4 lay 1.0-fold (0.01 log units) above the measured number, within the range that was stated.
By their numbers in this assay, from the lowest: compounds 2 and 4 (each within the scatter of the next); then compounds 3 and 1 (each within the scatter of the next).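

In this assay the low number is no longer confined to cyclohexyl, since a 4.0-fold lower number from compound 3 to compound 4 (0.60 log units; beyond the scatter) and an 8.0-fold lower number from compound 1 to compound 4 (0.90 log units; beyond the scatter) both lie beyond the scatter. The step of a 2.0-fold higher number from compound 2 to compound 4 (0.30 log units; within the scatter) lies within the scatter, so cyclopentyl and cyclohexyl cannot be told apart at this position, and the compounds shown fall into two sets: those with a ring of carbon here, and those with vinyl or propyl. Nothing measured here explains this split.

The compounds shown leave open where a smaller ring such as cyclopropyl, or an aromatic ring such as phenyl, would fall. They also leave open whether a longer chain such as hexyl would go with the lower numbers, which would tell whether the ring itself or only the added carbon goes with them.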